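Extending the Acyl Chain: From Compound 3 to Compound 4

This account rests on a few compounds, and the source may have more. Where it says the series, first, only, none or still open, it means among the compounds named here.

Compound 3 `CCCCCCCCCC(=O)Nc1ccn([C@@H]2CO[C@H](CO)O2)c(=O)n1` holds the lowest of the three numbers measured in a functional assay on SW1573 cells (Homo sapiens) for cytotoxicity, read by sulforhodamine B assay, with a stated time of 72 h; a lower number here means a stronger inhibitor, a higher number a weaker inhibitor: compound 3 gives 40 nM, whereas compound 2 `CCCCCCCCC(=O)Nc1ccn([C@@H]2CO[C@H](CO)O2)c(=O)n1` gives 276 nM and compound 1 `CCCC(=O)Nc1ccn([C@@H]2CO[C@H](CO)O2)c(=O)n1` gives 8070 nM. Compound 4 `CCCCCCCCCCCC(=O)Nc1ccn([C@@H]2CO[C@H](CO)O2)c(=O)n1` differs from compound 3 by ethyl in place of hydrogen on a saturated chain carbon, nine bonds along the chain from a carbonyl carbon. Every measured step lengthened this same chain and lowered the number in this assay: a 29-fold lower number from compound 1 to compound 2 (1.47 log units; beyond the scatter), a 200-fold lower number from compound 1 to compound 3 (2.30 log units; beyond the scatter), and the methyl addition a 6.9-fold lower number from compound 2 to compound 3 (0.84 log units; beyond the scatter). The two longer additions were large, the methyl addition modest, so a further lengthening is expected to lower the number again, though by a more modest amount. Compound 4 is therefore expected to give an estimated 15 nM in this assay, within a range from 4 nM to 60 nM. That expectation corresponds to a 2.7-fold lower number from compound 3 to compound 4 (0.43 log units; beyond the scatter).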

Compound 4, half-maximal inhibitory concentration: 30 nM
Beside the measured number, compound 4's estimate is 2.0-fold (0.30 log units) below it, and the stated range covers the measured number.
By their numbers in this assay, from the lowest: compounds 4 and 3 (each within the scatter of the next); then compound 2; then compound 1.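

In this assay the ethyl on this saturated chain carbon, nine bonds along the chain from a carbonyl carbon, gives a 1.3-fold lower number from compound 3 to compound 4 (0.12 log units; within the scatter) and so, unlike the earlier lengthenings, no difference beyond the scatter. Measured from the shorter chains, the spans remain beyond the scatter, with a 9.2-fold lower number from compound 2 to compound 4 (0.96 log units; beyond the scatter) and a 270-fold lower number from compound 1 to compound 4 (2.43 log units; beyond the scatter) as the chain grows, but the last addition adds nothing readable to them. No evidence at hand accounts for this levelling. The compounds shown leave open whether a longer chain would hold this level, and what a branched chain or a terminal amine would do.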